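Swapping a dichlorobenzyl for a tolyl on the sulfur

A few compounds are considered here, and "the series" means these few. Any claim that something is new, unique, unknown or untested is made for them only; others in the source may bear on it.

Measured compounds:
compound 1 `Cc1ccc(S/C(=C/c2c[nH]c3ccccc23)C(=O)c2ccc(Cl)cc2)cc1` gives 10000 nM
compound 2 `O=C(/C(=C\c1c[nH]c2ccc(Br)cc12)SCc1ccc(F)cc1)c1ccc(Cl)cc1` gives 50000 nM
compound 3 `O=C(/C(=C\c1c[nH]c2ccc(Br)cc12)SCc1ccc(Cl)cc1Cl)c1ccc(Cl)cc1` gives 10000 nM

All three numbers come from a functional assay on DU-145 cells (Homo sapiens) for inhibition, read by trypan blue exclusion, with a stated time of 96 h; a higher number here means a weaker inhibitor of growth, a lower number a stronger inhibitor of growth. Compound 3 stands level with compound 1 at the digits shown, and the two of them sit together at the lower end of the three values, while compound 2 lies higher by a 5.0-fold lower number from compound 2 to compound 3 (0.70 log units; beyond the scatter). For the measured compounds named here, that is the only step known here, and it shows that exchanging one group on the sulfur-bearing side can move the number by a modest amount.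

Compound 4 `Cc1ccc(S/C(=C/c2c[nH]c3ccc(Br)cc23)C(=O)c2ccc(Cl)cc2)cc1` has not yet been measured. It differs from compound 3 in this way: 4-methylphenyl in place of 2,4-dichlorobenzyl on a sulfur. Going by the values given here, no measured pair shows this exact change, though compound 1 already carries the 4-methylphenyl on sulfur and gives the same value as compound 3. Since compound 1 gives 10000 nM and compound 3 gives 10000 nM, compound 4 is expected to land near both, with an expected step of no change at the digits printed from compound 3 to compound 4 (within the scatter). The estimate for compound 4 is 10000 nM, between 3000 nM and 30000 nM.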

Compound 4, concentration for 50% growth inhibition: 1000 nM
Beside the measured number, compound 4's estimate is 10-fold (1.00 log units) above it, and the stated range ends above it.
By their numbers in this assay, from the lowest: compound 4; then compounds 1 and 3 (each within the scatter of the next); then compound 2.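

In this assay the group on the sulfur turns out to matter more than the earlier step suggested: among the bromo compounds, 4-methylphenyl brings a 10-fold lower number from compound 3 to compound 4 (1.00 log units; beyond the scatter) and also a 50-fold lower number from compound 2 to compound 4 (1.70 log units; beyond the scatter), leaving compound 4 lowest of the four. The bromo matters too, with a 10-fold lower number from compound 1 to compound 4 (1.00 log units; beyond the scatter), so the equal values of compound 1 and compound 3, whose structures differ in two places, did not mean that either change was neutral. No measurement here explains why either change lowers the number.

From the compounds shown here alone, whether the bromo would give a similar step with a benzyl group on the sulfur remains open. So does the part played by the methyl itself, and whether an amine or a carboxylic acid on that ring would be tolerated.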